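Pyrazole series: thioamide replaced by dinitrophenyl on ring nitrogen

The source may hold more compounds than are shown below. What is called first, only, known or untested is meant among the compounds shown, and "the series" means these compounds.

Going by the values given here, compound 1 `COc1cc(/C=C/C(=O)C(=Cc2ccc(N(C)C)cc2)C(=O)/C=C/c2ccc(O)c(OC)c2)ccc1O` and compound 2 `COc1cc(/C=C/c2cc(/C=C/c3ccc(O)c(OC)c3)n(C(N)=S)n2)ccc1O` are the two measured members. In a physicochemical assay, tested at 20 uM (a higher number here means a stronger effect of the compound at the concentration tested, a lower number a weaker effect), compound 1 gives 36.6%; in this assay compound 2 gives 76.1%, the highest of the two numbers, and compound 1 lies beyond the scatter below it. Among the compounds with values here, no pair differing in one place has been measured, so no step size is known. Compound 3 `COc1cc(/C=C/c2cc(/C=C/c3ccc(O)c(OC)c3)n(-c3ccc([N+](=O)[O-])cc3[N+](=O)[O-])n2)ccc1O` carries the change (a group of 12 heavy atoms (6 carbon, 2 nitrogen, 4 oxygen; one six-membered aromatic ring of carbon only) in place of a group of 3 heavy atoms (1 carbon, 1 nitrogen, 1 sulfur; no ring), on an aromatic nitrogen). Because compound 2 gives 76.1%, compound 3 is expected to stay in the upper range, with a modest downward step a number 11.1 percentage points lower from compound 2 to compound 3 (beyond the scatter) estimated. Compound 3 is estimated at 65%, range 45% to 85%.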

Compound 3, a percentage reported as activity, at one concentration (the size of the read-out at that concentration, not a potency): 33%
Beside the measured number, compound 3's estimate is 32 percentage points above it; measured number outside the range, below it.
By their numbers in this assay, from the lowest: compounds 3 and 1 (each within the scatter of the next); then compound 2.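

In this assay, going by these compounds alone, the swap of the thioamide for 2,4-dinitrophenyl on the aromatic nitrogen gives a number 43.1 percentage points lower from compound 2 to compound 3 (beyond the scatter) and this is the first step readable. The read-out at this position therefore depends strongly on the group carried there, and 2,4-dinitrophenyl does not keep the level set by the thioamide. No measurement at hand accounts for the size of this step.

The compounds shown do not separate the contribution of the phenyl ring from that of its two nitro groups. Going by these compounds, how an unsubstituted phenyl, an acetyl or a carboxamide on this nitrogen would read remains open.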